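The source may report more compounds than this note shows. Statements on the series, on what has been measured and on what is new or still open speak of the compounds shown alone.

Within the data shown here, in a functional assay on MDA-MB-231 cells (Homo sapiens), read by microscopy and transwell migration, with a stated time of 24 h (a higher number here means a weaker inhibitor, a lower number a stronger inhibitor), compound 2 `COc1cc(-c2csc(NC(=O)c3cccc(OC)c3OC)n2)cc(OC)c1OC` gives 15000 nM, the only actual number so far. Compound 1 `COc1cc(-c2csc(NC(=O)c3ccc(Cl)cc3)n2)cc(OC)c1OC` is reported as > 25000 nM, which is a limit of the assay and not a number. Among the measured compounds shown here, the one measured step is an at least 1.6-fold lower number from compound 1 to compound 2 (0.22 log units; that floor lies within the scatter). For the measured compounds named here, it is the only evidence that bears on the next change, since it too alters the aryl group on the carbonyl carbon, but it is small and does not show what either methoxy group contributes on its own.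

Compound 3 `COc1cccc(C(=O)Nc2nc(-c3cc(OC)c(OC)c(OC)c3)cs2)c1` differs from compound 2 by hydrogen in place of methoxy on an aromatic carbon, so that 2,3-dimethoxyphenyl becomes 3-methoxyphenyl. Going by the values given here, with only that one small step to go on, no change beyond the scatter is expected in this assay, though a slight drift towards a weaker compound is possible. The expected step is a 1.2-fold higher number from compound 2 to compound 3 (0.08 log units; within the scatter). For compound 3 the estimated value is 18000 nM, with an expected range of 8000 nM to 40000 nM.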

Compound 3, half-maximal inhibitory concentration: 14000 nM
Compound 3: the middle estimate sits 1.3-fold (0.11 log units) above what was measured, and the stated range covers the measured number.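

In this assay, the methoxy group ortho to a large group can give way to hydrogen with no change beyond the scatter, at a 1.1-fold lower number from compound 2 to compound 3 (0.03 log units; within the scatter), so the 2,3-dimethoxyphenyl pattern is not required to keep the number at this level, something the earlier step could not separate from the effect of the second methoxy group. Set against 4-chlorophenyl on the carbonyl carbon, 3-methoxyphenyl gives an at least 1.7-fold lower number from compound 1 to compound 3 (0.25 log units; that floor lies within the scatter), so the compounds carrying methoxy groups on this ring are not established as stronger than the chloro compound. The value of compound 1 is a limit of the assay and not a number, and both steps from it can be read only as floors: the limit of > 25000 nM in this assay, at which 1 of the 3 values shown sits.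

What the one remaining methoxy group contributes stays open, since a plain phenyl on the carbonyl carbon does not appear among the compounds shown. Also open, as far as these compounds go, is how an amine or a carboxylic acid on this ring would read, and whether any change at this position can move the number beyond the scatter.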